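Cytotoxicity of a Semicarbazide Analogue Bearing a Bromophenyl Urea

This account rests on a few compounds, and the source may have more. Where it says the series, first, only, none or still open, it means among the compounds named here.

Compound 1 `COc1cc(NC(C)CCCNC(=O)/C(C)=C/c2ccccc2)c2ncccc2c1`, in an ADME assay on L6 cells (Rattus norvegicus) for cytotoxicity, read by resazurin assay, with a stated time of 70 h; a higher number here means a weaker inhibitor, a lower number a stronger inhibitor: > 250000 nM, a limit only.
Compound 2 `COc1cc(NC(C)CCCNC(=O)NNC(=O)/C=C/c2cccc(C(F)(F)F)c2)c2ncccc2c1`, in this assay: 10600 nM.
Compound 3 `COc1cc(NC(C)CCCNC(=O)NNC(=O)/C=C/c2cc(C(F)(F)F)cc(C(F)(F)F)c2)c2ncccc2c1`, in this assay: > 170000 nM, a limit only.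

Among the measured compounds shown here, compound 2 holds the only true number in this assay; the other two values are limits. Compound 4 `COc1cc(NC(C)CCCNC(=O)NNC(=O)Nc2ccc(Br)cc2)c2ncccc2c1` differs from compound 2 by (4-bromophenyl)amino in place of 2-(3-(trifluoromethyl)phenyl)ethenyl on a carbonyl carbon, a (4-bromophenyl)amino group entering on a carbonyl carbon whose other neighbour is an amide-type nitrogen. For the measured compounds named here, the one measured step, an at least 16-fold higher number from compound 2 to compound 3 (1.20 log units; beyond the scatter), alters another part and ends at the limit of > 170000 nM in this assay, at which 1 of the 3 values shown sits, so it bears only loosely here. Going by the values given here, no measured step swaps the group on that carbonyl. A modest rise is expected, a 2.8-fold higher number from compound 2 to compound 4 (0.45 log units; beyond the scatter). Compound 4 is therefore estimated at 30000 nM, within 8000 nM to 200000 nM.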

Compound 4, half-maximal inhibitory concentration: 38700 nM
Compound 4: the middle estimate sits 1.3-fold (0.11 log units) below what was measured; measured number inside the range.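

In this assay, (4-bromophenyl)amino in place of 2-(3-(trifluoromethyl)phenyl)ethenyl on a carbonyl carbon gives a 3.7-fold higher number from compound 2 to compound 4 (0.56 log units; beyond the scatter). Among the compounds shown here, this is the first measured change at this carbonyl carbon, and unlike the step to compound 3, it ends at a true number rather than a limit. The two groups differ in more than one feature, so this single step cannot assign the rise to any one of them. From the compounds shown here alone, how a carboxylic acid, an amine or a longer chain on that carbonyl carbon would behave remains open.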